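This account rests on a few compounds, and the source may have more. Where it says the series, first, only, none or still open, it means among the compounds named here.

Measured so far in a functional assay on HOP-92 cells (Homo sapiens) for cytotoxicity, read by sulforhodamine B assay, with a stated time of 48 h, tested at 0.001 uM; on this read-out lower numbers stand for a stronger effect and higher numbers for a weaker effect at the one concentration tested:
Compound 1 `Cc1cc(O)cc(-c2nn(CC#N)cc2-c2ccnc(-c3ccc(Oc4ccccc4)cc3)c2)c1`, giving 74%
Compound 2 `COc1cc(C)cc(-c2nn(CC#N)cc2-c2ccnc(-c3ccc(N(C)C)cc3)c2)c1`, giving 102%

Within the data shown here, on these two numbers compound 2 stands highest; its only neighbour, compound 1, lies well below it, a gap beyond the usual scatter of repeated measurements. Since higher numbers mean a weaker effect, compound 2 is the weaker of the two at the one concentration tested.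

Compound 3 `Cc1cc(O)cc(-c2nn(CC#N)cc2-c2ccnc(-c3ccc(N(C)C)cc3)c2)c1` has not yet been measured. It differs from compound 2 in one place: hydrogen in place of methyl on an oxygen on an aromatic ring. Cut one bond further out, the difference reads methoxy to hydroxy, or 3-methoxy-5-methylphenyl to 3-hydroxy-5-methylphenyl. Compound 3 thus carries the same 3-hydroxy-5-methylphenyl group as compound 1, with the rest of compound 2 unchanged. Among the measured compounds shown here, no measured pair differs by exactly this change, so the size of the step is uncertain. Compound 1 carries that group and gives 74%, which is the ground for expecting a small to moderate move toward lower numbers in this assay, although a step within the scatter is also possible. The expected step is a number 12 percentage points lower from compound 2 to compound 3 (beyond the scatter). For compound 3 the estimate is 90%, with a range from 65% to 110%.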

Compound 3, a percentage reported as activity, at one concentration (the size of the read-out at that concentration, not a potency): 80%
Beside the measured number, compound 3's estimate is 10 percentage points above it; the measured number falls inside the stated range.
By their numbers in this assay, from the lowest: compounds 1 and 3 (each within the scatter of the next); then compound 2.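

In this assay, among these compounds, the change from methoxy to hydroxy on the 3-methoxy-5-methylphenyl group, with the dimethylamino group held fixed, gives a step of a number 22 percentage points lower from compound 2 to compound 3 (beyond the scatter), the first clean reading of this oxygen: losing the methyl changes the read-out by more than the usual scatter. The other single change, dimethylamino in place of phenoxy on an aromatic carbon with the hydroxy group held fixed, reads a number 6 percentage points higher from compound 1 to compound 3 (within the scatter), so with the hydroxy group in place this exchange cannot be told apart from the scatter of repeated measurements. Nothing in the data explains why either change has the size it does.

The compounds shown leave open whether the methoxy to hydroxy step would have the same size with phenoxy in place of dimethylamino, since the evidence for it rests on a single pair. They also leave open how this oxygen would respond to a longer chain such as ethoxy, or how the read-out would move with an amine or a carboxylic acid in place of the hydroxy group.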